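A New Phenyl Group on the Shared Core

The source may report more compounds than this note shows. Statements on the series, on what has been measured and on what is new or still open speak of the compounds shown alone.

In a functional assay on DU-145 cells (Homo sapiens) for antiproliferative activity, read by CCK-8 assay, with a stated time of 72 h (a higher number here means a weaker inhibitor, a lower number a stronger inhibitor), compound 1 `Cc1cc(Nc2cc(N3CCN(C)CC3)nc(Nc3ccc(Cl)cc3)n2)n[nH]1` gives 2240 nM as its half-maximal inhibitory concentration, and compound 2 `COc1cccc(Nc2nc(Nc3cc(C)[nH]n3)cc(N3CCN(C)CC3)n2)c1` gives 2650 nM on the same read-out. Among the measured compounds shown here, compound 2 therefore stands level with compound 1, the only other measured compound: the measured change is a 1.2-fold higher number from compound 1 to compound 2 (0.07 log units; within the scatter) and so the two cannot be ranked.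

Compound 3 `Cc1cc(Nc2cc(N3CCN(C)CC3)nc(Nc3ccc(C#N)cc3)n2)n[nH]1` has not yet been measured. It keeps the shared core and differs from compound 2 in one place 4-cyanophenyl in place of 3-methoxyphenyl on a nitrogen on an aromatic ring with 4-cyanophenyl in place of 3-methoxyphenyl on a nitrogen on an aromatic ring.

For the measured compounds named here, only the step between compound 1 and compound 2 bears on this, since it changes the group at that same place. One step within the scatter is a thin guide, and neither measured compound carries 4-cyanophenyl. Even so, no shift beyond the scatter is expected in this assay for this change. The estimated change is a 1.1-fold lower number from compound 2 to compound 3 (0.04 log units; within the scatter) and so stays small. Compound 3 is expected near 2400 nM with an estimated range from 900 nM to 6500 nM for its value.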

Compound 3, half-maximal inhibitory concentration: 1270 nM
For compound 3 the middle estimate is 1.9-fold (0.28 log units) above the measured one; the range from low to high includes it.
By their numbers in this assay, from the lowest: compounds 3, 1 and 2 (each within the scatter of the next, the first and the last beyond it).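

Among the compounds shown here, the aryl group on this nitrogen can shift the result in this assay: the change to 4-cyanophenyl gives a 2.1-fold lower number from compound 2 to compound 3 (0.32 log units; beyond the scatter) and is the first step here beyond the scatter, although only a modest one. The comparison with compound 1 tempers this, since cyano in place of chloro gives a 1.8-fold lower number from compound 1 to compound 3 (0.25 log units; within the scatter) and that step stays within the scatter, so compound 1 and compound 3 cannot be ranked. Compound 3 is therefore separated only from compound 2, and nothing available explains that difference.

The names 3-methoxyphenyl and 4-cyanophenyl differ in both the group and its number on the ring, so the step from compound 2 to compound 3 cannot show which of those two differences matters. From the compounds shown here alone, it also remains open how this nitrogen's aryl group would behave with a carboxylic acid, an amide or a simple amine on the ring, or with a plain phenyl carrying no added group at all.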